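The source may hold more compounds than are shown below. What is called first, only, known or untested is meant among the compounds shown, and "the series" means these compounds.

Measured so far:
- compound 1 `O=S(=O)(/C=C/c1ccc(Cl)c(Cl)c1)Cc1ccc(Nc2ncnc3ccccc23)cc1` – 14000 nM
- compound 2 `O=S(=O)(/C=C/c1ccc(Cl)cc1)Cc1ccc(Nc2ncnc3ccccc23)cc1` – > 100000 nM (a limit of the assay)

Among the measured compounds shown here, in a functional assay on OVCAR-8 cells (Homo sapiens) (on this read-out higher numbers stand for weaker inhibition of growth and lower numbers for stronger inhibition of growth), compound 1 gives 14000 nM, the only actual number so far. Compound 2 reads > 100000 nM, which is a limit and not a number.

Compound 3 `O=S(=O)(/C=C/c1ccc(Cl)c(Cl)c1)Cc1ccc(Nc2ncnc3ccc(Br)cc23)cc1` keeps everything in compound 1 except for one change bromo in place of hydrogen on an aromatic carbon, on a six-membered aromatic ring of carbon only, part of a fused or bridged system of two rings.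

For the measured compounds named here, only one measured step bears on this. It is an at least 7.1-fold higher number from compound 1 to compound 2 (0.85 log units; beyond the scatter), with hydrogen in place of chloro on an aromatic carbon, and it shows that the series can respond to a single halogen. That step lies at a different place and runs the opposite way, so it gives only weak guidance. A small move toward a lower number in this assay is expected, not clearly beyond the scatter. The expected step is a 1.8-fold lower number from compound 1 to compound 3 (0.24 log units; within the scatter). For compound 3 the estimated value is 8000 nM, with an expected range of 2000 nM to 35000 nM.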

Compound 3, concentration for 50% growth inhibition: 100 nM
The estimate for compound 3 lay 80-fold (1.90 log units) above the measured number; the whole stated range lies above it.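

In this assay, this position, on the carbon-only aromatic ring of the fused system, meta to a fused ring and para to a fused ring, proves highly responsive, with a 140-fold lower number from compound 1 to compound 3 (2.15 log units; beyond the scatter) for the single added bromo. The pair of compound 1 and compound 2 showed sensitivity to a halogen only at a different place, and only as a loss of growth inhibition, whereas this change shows that one halogen atom on the core of compound 1 can also strengthen growth inhibition by a large margin. The reading for compound 2 is a limit and not a number, so the earlier step can be read only as a bound, and its size cannot be set against the new step: the limit of > 100000 nM in this assay, at which 1 of the 3 values shown sits.

With bromo as the only group shown at this position, it remains open whether the gain is specific to bromo or would also appear with a chloro, a methoxy or an amine there. Also open, from the compounds shown here alone, is whether the same gain holds at the other ring carbons or without the second chloro of compound 1.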